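Series notes: 4-fluorophenyl to 2,3-dihydroxypropyl on ring nitrogen

This account rests on a few compounds, and the source may have more. Where it says the series, first, only, none or still open, it means among the compounds named here.

Compound 1 `Fc1ccc(-n2cc(CSc3nc4ccccc4s3)nn2)cc1` stands highest of the two measured compounds; in a functional assay on the whole organism (strain Albino Wistar) for inhibition, with Rattus norvegicus as the target, read by paw edema, with stated times of 1 h and 3 h, at a dose of 10 mg/kg by the oral route (a higher number here means more inhibition at the dose given (going by the name of the read-out), a lower number less inhibition), compound 1 gives 77.8%. Compound 2 `O[C@@H]1[C@H](O)[C@@H](O)OC(Cn2cc(CSc3nc4ccccc4s3)nn2)[C@@H]1O` carries a different group on the same ring nitrogen, and in this assay compound 2 gives 63.3%, a gap beyond the scatter. Compound 3 `OCC(O)Cn1cc(CSc2nc3ccccc3s2)nn1` is not yet measured; it differs from compound 1 by 2,3-dihydroxypropyl in place of 4-fluorophenyl on an aromatic nitrogen. For the measured compounds named here, no step between measured pairs is recorded, so a downward step beyond the scatter is expected, guided by compound 2 because its value 63.3% falls short of compound 1. The step of a number 15.8 percentage points lower from compound 1 to compound 3 (beyond the scatter) is expected. For compound 3 the estimate is 62%, between 48% and 76%.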

Compound 3, a percentage reported as inhibition, in the whole organism at one dose (the size of the read-out at that dose, not a potency): 56.7%
Compound 3: the middle estimate sits 5.3 percentage points above what was measured, and the stated range covers the measured number.
By their numbers in this assay, from the lowest: compounds 3 and 2 (each within the scatter of the next); then compound 1.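

For the compounds shown here, on an aromatic nitrogen of the shared core, 2,3-dihydroxypropyl in place of 4-fluorophenyl gives a number 21.1 percentage points lower from compound 1 to compound 3 (beyond the scatter) in this assay, the first single-place step. An open-chain group without a ring therefore keeps inhibition at this position, with compound 3 at 56.7%, though it does not match the aryl group. No measurement here accounts for the step.

On these data alone, whether the step follows loss of the aromatic ring or the entry of the hydroxyl groups stays open. A plain propyl chain or a benzyl group on the same nitrogen would separate the two.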